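The source may report more compounds than this note shows. Statements on the series, on what has been measured and on what is new or still open speak of the compounds shown alone.

Measured compounds:
Compound 1, `O=C(CSc1nc(Nc2ccccc2)c2ccccc2n1)Nc1ccccc1Cl`: 14600 nM
Compound 2, `O=C(CSc1nc(Nc2ccccc2)c2ccccc2n1)Nc1cccc(Cl)c1`: 12600 nM

In a functional assay on PC-3 cells (Homo sapiens) for inhibition, read by MTT assay, with a stated time of 72 h (on this read-out lower numbers stand for stronger inhibition and higher numbers for weaker inhibition), compound 2 gives 12600 nM, the lowest of the two numbers, while compound 1 gives 14600 nM. Going by the values given here, the only measured step, a 1.2-fold lower number from compound 1 to compound 2 (0.06 log units; within the scatter), changes where the chloro group sits and nothing else. The unmeasured compound 3, `O=C(CSc1nc(Nc2ccccc2)c2ccccc2n1)Nc1cccc([N+](=O)[O-])c1`, differs from compound 2 by nitro in place of chloro on an aromatic carbon. Among the compounds with values here, no measured step involves a nitro group, so the data give no direct guide; the one step available was within the scatter, which suggests that changes of a single group on this ring have so far left the number close to where it was. Compound 3 is therefore expected to give about 12600 nM in this assay, with a range from 5000 nM to 32000 nM. This estimate amounts to no change at the digits printed from compound 2 to compound 3 (within the scatter), a step expected to stay within the scatter.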

Compound 3, half-maximal inhibitory concentration: 11800 nM
Estimate against measurement, compound 3: 1.1-fold (0.03 log units) above; measured number inside the range.
By their numbers in this assay, from the lowest: compounds 3, 2 and 1 (each within the scatter of the next).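

In this assay, going from 3-chlorophenyl to 3-nitrophenyl gives a 1.1-fold lower number from compound 2 to compound 3 (0.03 log units; within the scatter), so the second kind of group tried at this place, with more heavy atoms and with hydrogen-bond acceptors that chloro lacks, leaves the number within the scatter. The wider change, which alters both the group and its place on the ring, gives a 1.2-fold lower number from compound 1 to compound 3 (0.09 log units; within the scatter), and so 2-chlorophenyl, 3-chlorophenyl and 3-nitrophenyl on the amide-type nitrogen are not told apart by this read-out. Nothing measured here speaks to why these three compounds stay so close.

The compounds shown leave open whether an amine or a carboxylic acid on this ring would move the number beyond the scatter. They also leave open whether any change outside this ring, such as a methoxy group on the other phenyl group of the shared core, would do so.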